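From compound 1 to compound 4: estimating growth inhibition

This account rests on a few compounds, and the source may have more. Where it says the series, first, only, none or still open, it means among the compounds named here.

In a functional assay on NCI/ADR cells (Homo sapiens) for cytotoxicity, read by sulforhodamine B assay (a higher number here means a weaker inhibitor of growth, a lower number a stronger inhibitor of growth), compound 1 (`CC1=CC[C@@H]([C@@](C)(O)CCCC(C)(C)NC(=S)NN)CC1`) gives 29000 nM as its reading. Two compounds with the same core have also been measured: compound 2 (`CC1=CC[C@@H]([C@@](C)(O)CCCC(C)(C)NC(=S)N/N=C\c2ccccc2)CC1`) gives 23800 nM and compound 3 (`COc1ccc(/C=N\NC(=S)NC(C)(C)CCC[C@](C)(O)[C@@H]2CC=C(C)CC2)cc1`) gives 57000 nM in the same test. Compound 1 has the second highest of these three numbers, but its distance to each of the others lies within the scatter, so it cannot truly be ranked against either.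

Compound 4 (`CC1=CC[C@@H]([C@@](C)(O)CCCC(C)(C)NC(=S)N/N=C\c2ccc(O)cc2)CC1`) is still unmeasured. Its change from compound 1 is a group of 9 heavy atoms (7 carbon, 1 nitrogen, 1 oxygen; one six-membered aromatic ring of carbon only) in place of one nitrogen atom, on an amide-type nitrogen on an amide-type nitrogen whose other neighbour is the thiocarbonyl carbon. Two measured steps swap the same nitrogen for a group that also holds a six-membered aromatic ring of carbon only: a 1.2-fold lower number from compound 1 to compound 2 (0.09 log units; within the scatter) and a 2.0-fold higher number from compound 1 to compound 3 (0.29 log units; within the scatter) are both small. Going by the values given here, the one step beyond the scatter, a 2.4-fold higher number from compound 2 to compound 3 (0.38 log units; beyond the scatter), is modest and comes from methoxy in place of hydrogen on an aromatic carbon. No step beyond the scatter is therefore expected in this assay for this change.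

For compound 4 the expected step is a 1.0-fold higher number from compound 1 to compound 4 (0.01 log units; within the scatter) in size.

For compound 4 the estimated value is 30000 nM, with an expected range from 15000 nM to 60000 nM.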

Compound 4, concentration for total growth inhibition: 6070 nM
The estimate for compound 4 lay 4.9-fold (0.69 log units) above the measured number; the whole stated range lies above it.
By their numbers in this assay, from the lowest: compound 4; then compounds 2, 1 and 3 (each within the scatter of the next, the first and the last beyond it).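

Going by these compounds alone, the group on the amide-type nitrogen whose other neighbour is the thiocarbonyl carbon matters more in this assay than the earlier compounds suggested: adding a hydroxy to the aromatic ring gives a 3.9-fold lower number from compound 2 to compound 4 (0.59 log units; beyond the scatter), and the whole exchange of the amino group gives a 4.8-fold lower number from compound 1 to compound 4 (0.68 log units; beyond the scatter), so compound 4 is the strongest inhibitor of growth among the four. What sits on the oxygen also counts, since hydrogen in place of methyl gives a 9.4-fold lower number from compound 3 to compound 4 (0.97 log units; beyond the scatter), and the hydroxy and methoxy groups move the number in opposite directions from compound 2, whose step to the methoxy compound is a 2.4-fold higher number from compound 2 to compound 3 (0.38 log units; beyond the scatter). Nothing available explains these steps or shows what lies behind the difference between the two oxygen groups.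

With only hydrogen, hydroxy and methoxy shown on the aromatic ring, it remains open whether an amine, a fluorine or a carboxylic acid in place of the hydroxy would behave like compound 4 or like compound 3. Going by these compounds, it is also open whether a second hydroxy on the ring would lower the number further, and whether the gain from the hydroxy would carry over to a different core.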